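This account rests on a few compounds, and the source may have more. Where it says the series, first, only, none or still open, it means among the compounds named here.

In a functional assay (trachea) with Cavia porcellus as the target (on this read-out lower numbers stand for an effect already at smaller amounts and higher numbers for an effect only at larger amounts of compound), compound 3 (`CCCn1c(=O)n(C)c(=O)c2[nH]cnc21`) gives 1600 nM, the second highest of three numbers. Compound 1 (`CCCn1c(=O)n(CCOC)c(=O)c2[nH]cnc21`) gives 700 nM, and compound 2 (`CCCn1c(=O)n(CC(C)=O)c(=O)c2[nH]cnc21`) gives 14900 nM. Compound 4 (`CCCn1cnc2c1c(=O)n(C)c(=O)n2CCC`) is still unmeasured. It has propyl in place of hydrogen on an aromatic nitrogen of compound 3: propyl in place of hydrogen on an aromatic nitrogen. Among the measured compounds shown here, all three measured compounds keep that hydrogen, so no measured step tests this change directly. The available steps all fall on a saturated chain carbon bound to an aromatic nitrogen, and they bear on it only loosely. The large one is a 21-fold higher number from compound 1 to compound 2 (1.33 log units; beyond the scatter), followed by a 9.3-fold lower number from compound 2 to compound 3 (0.97 log units; beyond the scatter) and the smaller 2.3-fold higher number from compound 1 to compound 3 (0.36 log units; beyond the scatter). They show that a single change can move this series a long way upward, while the lowest number lies only a 2.3-fold higher number from compound 1 to compound 3 (0.36 log units; beyond the scatter). A modest step towards a higher number in this assay is therefore expected, with little certainty about its direction. The estimate amounts to an expected 2.5-fold higher number from compound 3 to compound 4 (0.40 log units; beyond the scatter). For compound 4 the estimated value is 4000 nM, with an expected range of 1200 nM to 15000 nM.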

Compound 4, half-maximal effective concentration: 5000 nM
The estimate for compound 4 lay 1.3-fold (0.10 log units) below the measured number; low and high end bracket the measured number.
By their numbers in this assay, from the lowest: compound 1; then compound 3; then compound 4; then compound 2.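

The hydrogen on the aromatic nitrogen of the five-membered ring can give way to propyl with an effect still recorded in this assay, although the change brings a 3.1-fold higher number from compound 3 to compound 4 (0.49 log units; beyond the scatter). Among the compounds shown here, this is the first reading at this nitrogen, which all the earlier compounds left untouched, and it shows that this position also moves the number, and that propyl here costs a modest amount of effect rather than abolishing it. No data at hand give a reason for this rise.

Open, going by these compounds, is how a methyl group, a butyl chain or a chain ending in an amine would compare with propyl on this nitrogen. Also open, on these data alone, is whether propyl would shift the number by a similar step on compound 1 or compound 2, which both keep the hydrogen.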